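Aryl swap at the hydrazone carbon of the shared series

This account rests on a few compounds, and the source may have more. Where it says the series, first, only, none or still open, it means among the compounds named here.

Three compounds have been taken through an ADME assay on WI-38 cells (Homo sapiens) for cytotoxicity, read by MTT assay, with a stated time of 72 h; on this read-out higher numbers stand for weaker inhibition and lower numbers for stronger inhibition. Compound 2 `CN(C)CCn1cnnc1-c1cc(Oc2ccc(NC(=O)N/N=C/c3ccc(F)cc3Cl)cc2F)ccn1` gives 2090 nM in this assay. Compound 1 `COc1ccc(OC)c(/C=N/NC(=O)Nc2ccc(Oc3ccnc(-c4nncn4CCN(C)C)c3)c(F)c2)c1` gives "not determined" (no result reported) in this assay, and compound 3 `CN(C)CCn1cnnc1-c1cc(Oc2ccc(NC(=O)N/N=C/c3ccc(O)c(O)c3)cc2F)ccn1` likewise gives "not determined" (no result reported) there, so compound 2 stands as the only number shown, with nothing alongside it to rank against and no step between measured compounds to draw on.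

The new entry is compound 4 `CN(C)CCn1cnnc1-c1cc(Oc2ccc(NC(=O)N/N=C/c3ccccc3O[N+](=O)[O-])cc2F)ccn1`, which differs from compound 2 in one place only: 2-(nitrooxy)phenyl in place of 2-chloro-4-fluorophenyl on a carbon with a double bond to nitrogen. Everything else in the shared core, including the urea and the ether link, is kept.

Within the data shown here, with no measured step available in this assay, the size of the change from compound 2 to compound 4 can only be guessed. The expectation is that the step of a 1.2-fold higher number from compound 2 to compound 4 (0.08 log units; within the scatter) stays within the usual scatter of this assay, with no clear direction, because the lone anchor for the series is compound 2 at 2090 nM and no second number is there to set a trend. On that basis compound 4 is estimated at 2500 nM in this assay, with a range from 800 nM to 8000 nM.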

Compound 4, half-maximal inhibitory concentration: 6860 nM
The estimate for compound 4 lay 2.7-fold (0.44 log units) below the measured number; measured number inside the range.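

Among these compounds, changing the aryl group on the carbon with a double bond to nitrogen moves the read-out in this assay: 2-(nitrooxy)phenyl in place of 2-chloro-4-fluorophenyl gives a 3.3-fold higher number from compound 2 to compound 4 (0.52 log units; beyond the scatter), the first step in this set that can be read and one that lies beyond the scatter. This swap removes both halogens and brings in one nitrogen and three oxygens, taking the group from 8 to 10 heavy atoms and from 0 to 3 hydrogen-bond acceptors, with hydrogen-bond donors at 0 on both sides, so a single step cannot show which of these differences matters. Nothing available bears on the reason for the shift.

Steps involving compound 1 and compound 3 cannot be read, so this one step sets no trend across the aryl groups at this position. As far as these compounds go, whether the higher number belongs to the nitrooxy group itself or to the loss of the chlorine and fluorine remains open, a question that an unsubstituted phenyl, or a phenyl carrying a nitro group or an amine, would help to separate.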